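Moving a Methyl on the Aryl Group: Expected Cytotoxicity

The source may hold more compounds than are shown below. What is called first, only, known or untested is meant among the compounds shown, and "the series" means these compounds.

Compound 2 `Cc1cccc(-c2cc(C(=O)N3CCC(Cc4ccccc4)CC3)c3ccccc3n2)c1` was tested in an ADME assay on HepG2 2.2.15 cells (Homo sapiens) for cytotoxicity, read by MTT assay, with stated times of 3 days and 7 days (on this read-out higher numbers stand for lower toxicity in this test and lower numbers for higher toxicity in this test), and gives only a limit of > 20000 nM there. Compound 1 `COc1ccc(-c2cc(C(=O)OCc3ccccc3)c3ccccc3n2)cc1` likewise gives only a limit of > 20000 nM in this assay. Compound 2 thus stands at the limit of > 20000 nM in this assay, at which 2 of the 2 values shown sit, so no order between the two can be read. Compound 3 `Cc1ccc(-c2cc(C(=O)N3CCC(Cc4ccccc4)CC3)c3ccccc3n2)cc1` differs from compound 2 by 4-methylphenyl in place of 3-methylphenyl on an aromatic carbon. Among the measured compounds shown here, no measured step points one way, so the expected change is none beyond the scatter, a number no higher from compound 2 to compound 3 (the limit leaves the size open). Compound 3 is therefore estimated at 20000 nM, within 10000 nM to 50000 nM, most likely again reported only as a limit.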

Compound 3, half-maximal cytotoxic concentration: > 20000 nM
Compound 3 was reported as a limit; the forecaster's own chance of this, stated with the estimate: 85%; the middle value lies on the limit itself.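

Compound 2 and compound 3 are both reported only as limits, so no step can be read between them: the limit of > 20000 nM in this assay, at which 3 of the 3 values shown sit.

The compounds shown leave open whether 3-methylphenyl and 4-methylphenyl differ at all in this assay.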